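The compounds below may be only part of what the source reports. "The series", "measured", "known", "first", "only" and "open" are said of these compounds alone.

For the measured compounds named here, compound 3 `COc1ccc(-c2cc(C(C)(C)C)cc(C(C)C)c2CO)cc1` is one of three compounds measured in a functional assay on RKE cells for antagonist activity at Vasoactive intestinal polypeptide receptor 1 (Rattus norvegicus), read by HTRF and cAMP accumulation, with stated times of 10 min and 30 min; on this read-out lower numbers stand for stronger inhibition and higher numbers for weaker inhibition. Compound 3 gives 1300 nM, the second highest of the three numbers. Its nearest neighbour is compound 1 `CC(C)c1cc(C(C)(C)C)cc(-c2ccc(F)cc2)c1CO`, which in this assay gives 740 nM; the step of a 1.8-fold higher number from compound 1 to compound 3 (0.24 log units; within the scatter) comes from methoxy in place of fluoro on an aromatic carbon. The furthest is compound 2 `CCC(=O)Nc1sc2c(c1C#N)CCCC2`, which in this assay gives 12000 nM, a number beyond the scatter from that of compound 3.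

Compound 4 `CC(C)c1cc(C(C)(C)C)cc(-c2ccc(-c3ccccc3)cc2)c1CO` has not been measured. Compared with compound 3 the change is phenyl in place of methoxy on an aromatic carbon. Going by the values given here, only one measured step bears on this place on the shared core, the step of a 1.8-fold higher number from compound 1 to compound 3 (0.24 log units; within the scatter), and it stayed within the scatter; no measured compound carries a phenyl at this place, so the data say nothing about a group of that size. Compound 4 is therefore expected to give a number near that of compound 3, an estimated step of a 1.3-fold lower number from compound 3 to compound 4 (0.11 log units; within the scatter). The estimate for compound 4 in this assay is 1000 nM, with a range from 300 nM to 4000 nM.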

Compound 4, half-maximal inhibitory concentration: 680 nM
For compound 4 the middle estimate is 1.5-fold (0.17 log units) above the measured one; measured number inside the range.
By their numbers in this assay, from the lowest: compounds 4, 1 and 3 (each within the scatter of the next); then compound 2.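

At this place on the shared core, para to a large group, phenyl with its six heavy atoms and aromatic ring in place of the two heavy atoms of methoxy gives a 1.9-fold lower number from compound 3 to compound 4 (0.28 log units; within the scatter), while phenyl in place of fluoro gives a 1.1-fold lower number from compound 1 to compound 4 (0.04 log units; within the scatter). For the compounds shown here, the one earlier step at this place compared only fluoro and methoxy; the series now includes a substituent with a ring of its own, and all three groups remain within the scatter of one another. No measurement shown here accounts for this result.

Going by these compounds, whether an amine, a carboxylic acid or a longer chain at this place would also stay within the scatter remains open. The compounds shown also leave open how changes elsewhere on the shared core would affect these numbers.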